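Shifting the Ring on the Amide Nitrogen: Compound 3

A few compounds are considered here, and "the series" means these few. Any claim that something is new, unique, unknown or untested is made for them only; others in the source may bear on it.

Compound 1 `O=C1CC(c2nc(-c3cccc(Cl)c3)no2)CN1c1ccccc1Cl` and compound 2 `O=C1CC(c2nc(-c3cccc(Cl)c3)no2)CN1c1ccc(Cl)cc1` share one core and differ only in the ring held on an amide-type nitrogen in a ring. In an in vitro functional assay on HEK293-A cells for positive allosteric modulation of metabotropic glutamate receptor 5 (Homo sapiens), read by FLIPR and calcium flux (on this read-out higher numbers stand for an effect only at larger amounts of compound and lower numbers for an effect already at smaller amounts), compound 1 reaches only > 10000 nM, which is a limit of the assay and not a number. In this assay compound 2 gives 140 nM. The step between them is an at least 71-fold lower number from compound 1 to compound 2 (1.85 log units; beyond the scatter), and its size is capped by the limit of > 10000 nM in this assay, at which 1 of the 2 values shown sits, so the true gap may be wider still. Among the values shown, compound 2 stands as the only one with a number; the other entry is a limit.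

Compound 3 `Cc1cccc(N2CC(c3nc(-c4cccc(Cl)c4)no3)CC2=O)c1` carries 3-methylphenyl in place of 4-chlorophenyl on an amide-type nitrogen in a ring. For the measured compounds named here, the single measured step, from compound 1 to compound 2, shows that the ring on this nitrogen matters greatly, yet it compares two chlorophenyl rings, whereas here a 3-methylphenyl enters. That step therefore gives direction only loosely. Compound 3 is expected to show a 3.2-fold higher number from compound 2 to compound 3 (0.51 log units; beyond the scatter), a modest loss with wide uncertainty. In this assay compound 3 is estimated at 450 nM, between 100 nM and 3000 nM.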

Compound 3, half-maximal effective concentration: > 10000 nM
Compound 3: only a limit was reported; the forecaster's own chance of this, stated with the estimate: 15%; middle value at least 22-fold (1.34 log units) from the limit.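

In this assay, replacing the 4-chlorophenyl of compound 2 with 3-methylphenyl gives an at least 71-fold higher number from compound 2 to compound 3 (1.85 log units; beyond the scatter), so activity here does not survive every change to the ring on this amide-type nitrogen. Of the three rings shown at this position, only 4-chlorophenyl gives a number, whereas 2-chlorophenyl in compound 1 and 3-methylphenyl in compound 3 both end at a limit of the assay, so the earlier contrast between two chlorophenyl rings now extends to a ring with no chlorine. The step from compound 1 to compound 3 cannot be read, and the step from the 4-chlorophenyl compound to the 3-methylphenyl compound may be wider still: the limit of > 10000 nM in this assay, at which 2 of the 3 values shown sit.

The change from compound 2 to compound 3 swaps the chlorine for a methyl group and also moves the substituent on the ring, so the compounds shown cannot tell which of these two differences accounts for the loss. From the compounds shown here alone, a 4-methylphenyl or 4-fluorophenyl ring on this nitrogen would separate those two differences, and how either would behave remains open.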